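The source may hold more compounds than are shown below. What is called first, only, known or untested is meant among the compounds shown, and "the series" means these compounds.

Of the compounds shown here, two with a shared core have been measured in an assay on NIH3T3 cells with Urotensin-2 receptor (Homo sapiens) as the target; a higher number here means that more compound is needed for the effect, a lower number that less compound is needed. Compound 1 `Cc1ccccc1C(=O)OC(CCN(C)C)c1ccc(Cl)cc1` carries an ester; in this assay compound 1 gives 1700 nM. Compound 2 `Cc1ccccc1C(=O)NC(CCN(C)C)c1ccc(Cl)cc1` carries the corresponding amide, and in this assay compound 2 gives 3550 nM. Of the two numbers, that of compound 2 is the higher one, and the gap between it and compound 1 lies beyond the usual scatter of the assay; no more than that can be read from the pair.

Compound 3 `Cc1cccc(C(=O)NC(CCN(C)C)c2ccc(Cl)cc2)c1C` has not yet been measured in this assay. It differs from compound 2 by a single change, (methyl in place of hydrogen on an aromatic carbon), placed on an aromatic carbon of a six-membered aromatic ring of carbon only, ortho to a methyl group and meta to a large group. Among the measured compounds shown here, nothing among the measured compounds shows what such a change does here, so the expected step from compound 2 to compound 3 is a 1.2-fold lower number from compound 2 to compound 3 (0.07 log units; within the scatter), a step not expected to go beyond the scatter in either direction. On that basis compound 3 is estimated at 3000 nM, with a range from 1000 nM to 9000 nM.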

Compound 3, half-maximal effective concentration: 3630 nM
For compound 3 the middle estimate is 1.2-fold (0.08 log units) below the measured one, within the range that was stated.
By their numbers in this assay, from the lowest: compound 1; then compounds 2 and 3 (each within the scatter of the next).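

Replacing hydrogen with methyl on an aromatic carbon, ortho to a methyl group and meta to a large group, turns 2-methylphenyl into 2,3-dimethylphenyl and gives a 1.0-fold higher number from compound 2 to compound 3 (0.01 log units; within the scatter) in this assay. The earlier pair showed only a swap of ester for amide and said nothing about this aromatic carbon, whereas this step shows that the position accepts one added methyl with no change beyond the scatter. The available data offer no explanation for this result.

On these data alone, one methyl is a single probe, so it remains open whether a different group at this position, such as ethyl, methoxy, an amine or a carboxylic acid, would also stay within the scatter of compound 2 or would move the number beyond it. As far as these compounds go, it is also open whether the same methyl would behave in the same way on the ester of compound 1, or on other aromatic carbons of this ring.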